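This account rests on a few compounds, and the source may have more. Where it says the series, first, only, none or still open, it means among the compounds named here.

Measured compounds in an assay on CHO cells for displacement of a labelled ligand from adenosine receptor A3 (Homo sapiens), read by scintillation counting, with a stated time of 3 h; a higher number here means a weaker inhibitor, a lower number a stronger inhibitor:
- compound 1, `CCCn1c(-c2ccccc2)nc2c(NC3CCC3)ncnc21`: 264 nM
- compound 2, `Cn1c(-c2ccc(O)cc2)nc2c(NC3CCCC3)ncnc21`: 521 nM
- compound 3, `Cc1ccc(-c2nc3c(NC4CCCC4)ncnc3n2C)cc1`: 480 nM

Compound 3 stands second highest of the three numbers in this assay; its nearest neighbour is compound 2 and its furthest is compound 1, and both gaps lie within the scatter. Among the compounds with values here, the only single-place step among the measured compounds is a 1.1-fold lower number from compound 2 to compound 3 (0.04 log units; within the scatter), which is within the scatter.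

Compound 4, `Cn1c(-c2ccccc2)nc2c(NC3CCCC3)ncnc21`, differs from compound 3 in one place: hydrogen in place of methyl on an aromatic carbon. Within the data shown here, no measured pair shows exactly this change. An unsubstituted phenyl is also carried by compound 1, which differs from compound 4 in two further places, so the value of compound 1, 264 nM, only indicates the range in which such compounds have fallen. Among the measured compounds shown here, the one step that touches the same carbon, from compound 2 to compound 3, stayed within the scatter, so a change at this position is expected to move this assay little; the estimated step is a 1.2-fold lower number from compound 3 to compound 4 (0.08 log units; within the scatter). For compound 4 a value of 400 nM is expected, with a range from 200 nM to 900 nM.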

Compound 4, inhibition constant: 846 nM
For compound 4 the middle estimate is 2.1-fold (0.33 log units) below the measured one; measured number inside the range.
By their numbers in this assay, from the lowest: compounds 1, 3, 2 and 4 (each within the scatter of the next, the first and the last beyond it).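

With hydrogen now at this carbon, three groups on the aromatic ring can be compared in this assay: the change from 4-methylphenyl to phenyl is a 1.8-fold higher number from compound 3 to compound 4 (0.25 log units; within the scatter), and replacing hydroxy with hydrogen is a 1.6-fold higher number from compound 2 to compound 4 (0.21 log units; within the scatter). Within the data shown here, both steps stay within the scatter, as did a 1.1-fold lower number from compound 2 to compound 3 (0.04 log units; within the scatter), so hydrogen, methyl and hydroxy at this place are not told apart in this assay, whereas the earlier compounds compared only methyl and hydroxy. No independent data bear on this result.

From the compounds shown here alone, whether an amine, a carboxylic acid or a longer chain at this carbon would move the number beyond the scatter remains open. Also open, going by these compounds, is whether the change from 4-methylphenyl to phenyl reads the same with the other substituents carried by compound 1.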